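A few compounds are considered here, and "the series" means these few. Any claim that something is new, unique, unknown or untested is made for them only; others in the source may bear on it.

Measured compounds:
- compound 1, `CCCOC(=O)Nc1ccc([Se]C#N)cc1`: 38400 nM
- compound 2, `Cc1ccc(OC(=O)Nc2ccc([Se][Se]c3ccc(NC(=O)Oc4ccc(C)cc4)cc3)cc2)cc1`: 48500 nM

Of the compounds shown here, two have been measured in a functional assay on CCRF-CEM cells (Homo sapiens) for cytotoxicity, read by MTT assay, with a stated time of 72 h; a lower number here means a stronger inhibitor of growth, a higher number a weaker inhibitor of growth. Compound 1 is `CCCOC(=O)Nc1ccc([Se]C#N)cc1`, and in this assay compound 1 gives 38400 nM. Compound 2 is `Cc1ccc(OC(=O)Nc2ccc([Se][Se]c3ccc(NC(=O)Oc4ccc(C)cc4)cc3)cc2)cc1`, and in this assay compound 2 gives 48500 nM. The two values lie within the usual scatter of each other, so compound 1 stands on a par with compound 2, and neither can be called the stronger inhibitor of growth.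

The step of interest leads from compound 1 to compound 3, `CCCCOC(=O)Nc1ccc([Se]C#N)cc1`, which has not yet been measured in this assay. The change is methyl in place of hydrogen on a saturated chain carbon, three bonds along the chain from an oxygen next to a carbonyl group. Among the measured compounds shown here, no measured pair shows what such a step does here. With only a single carbon entering on the chain, the expected step of a 1.1-fold lower number from compound 1 to compound 3 (0.04 log units; within the scatter) is small and, if anything, within the scatter. Compound 3 is therefore estimated at 35000 nM, with a range from 15000 nM to 80000 nM.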

Compound 3, concentration for total growth inhibition: 27900 nM
For compound 3 the middle estimate is 1.3-fold (0.10 log units) above the measured one; the range from low to high includes it.
By their numbers in this assay, from the lowest: compounds 3, 1 and 2 (each within the scatter of the next).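

In this assay, among the compounds shown here, the first measured step at this position, propyl to butyl, gives a 1.4-fold lower number from compound 1 to compound 3 (0.14 log units; within the scatter), so the two compounds stand level. This shows that methyl in place of hydrogen on a saturated chain carbon, three bonds along the chain from an oxygen next to a carbonyl group, is accepted here without a difference that can be told from the scatter, though this rests on a single pair. Nothing measured in this set bears on why the two compounds stand level.

Going by these compounds, whether a longer chain such as hexyl, or a chain carrying an amine or a carboxylic acid, would stay level with compound 3 remains open. On these data alone, it is also open whether the same step would read alike on another core.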